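Compound 3: nitro in place of methyl

The source may hold more compounds than are shown below. What is called first, only, known or untested is meant among the compounds shown, and "the series" means these compounds.

Compound 1 `OCc1cn(Cc2ccc(Cl)cc2)c2ccccc12`: > 31600 nM (a limit)
Compound 2 `Cc1ccc(Cn2cc(CO)c3ccccc32)cc1`: > 31600 nM (a limit)

In an ADME assay on T29 cells (Homo sapiens) for cytotoxicity, read by sulforhodamine B assay, with a stated time of 3 days (on this read-out higher numbers stand for weaker inhibition and lower numbers for stronger inhibition), compound 2 stands only at a limit, > 31600 nM. For the measured compounds named here, the same holds for the whole series so far: the limit of > 31600 nM in this assay, at which 2 of the 2 values shown sit. Compound 3 `O=[N+]([O-])c1ccc(Cn2cc(CO)c3ccccc32)cc1` differs from compound 2 by nitro in place of methyl on an aromatic carbon. Going by the values given here, the only measured step that bears on this is a step that the two limits leave unreadable from compound 1 to compound 2, also a change on an aromatic carbon. Since a step that the two limits leave unreadable from compound 1 to compound 2 has no readable size, neither a clear size nor a direction can be expected in this assay, and another limit is likely. The expected change is an at least 1.0-fold lower number from compound 2 to compound 3 (0.02 log units; that floor lies within the scatter). For compound 3 the estimate is 30000 nM, within an expected range of 10000 nM to 90000 nM.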

Compound 3, half-maximal inhibitory concentration: > 31600 nM
Compound 3: no number, only a limit (the forecaster's own chance of this, stated with the estimate: 70%); at least 1.0-fold (0.02 log units) between middle value and limit.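

No new step can be read between compound 1, compound 2 and compound 3, as all three rest on one limit: the limit of > 31600 nM in this assay, at which 3 of the 3 values shown sit.

From the compounds shown here alone, whether chloro, methyl and nitro on the aromatic carbon differ at all in this assay stays open.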